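Swapping one trimethoxyphenyl group for 3-nitrophenyl

This account rests on a few compounds, and the source may have more. Where it says the series, first, only, none or still open, it means among the compounds named here.

Compound 1 `COc1cc(/C=C2\CN(S(=O)(=O)c3ccc(F)cc3)C/C(=C\c3cc(OC)c(OC)c(OC)c3)C2=O)cc(OC)c1OC`: 3840 nM
Compound 2 `CC(=O)Nc1ccc(S(=O)(=O)N2C/C(=C\c3ccccc3F)C(=O)/C(=C/c3ccccc3F)C2)cc1`: 7490 nM
Compound 3 `COc1cc(/C=C2\CN(S(=O)(=O)c3ccc(NC(C)=O)cc3)C/C(=C\c3cc(OC)c(OC)c(OC)c3)C2=O)cc(OC)c1OC`: 3470 nM

These three compounds were tested in a functional assay on SMMC-7721 cells (Homo sapiens) for cytotoxicity, read by MTT assay, with a stated time of 24 h; on this read-out higher numbers stand for weaker inhibition and lower numbers for stronger inhibition. Compound 1, at 3840 nM, is second highest of the three numbers, though compound 2 and compound 3 both lie within the scatter of it. The next compound, compound 4 `COc1cc(/C=C2\CN(S(=O)(=O)c3ccc(F)cc3)C/C(=C\c3cccc([N+](=O)[O-])c3)C2=O)cc(OC)c1OC`, has not yet been measured. Its difference from compound 1 is 3-nitrophenyl in place of 3,4,5-trimethoxyphenyl on a double-bonded chain carbon bound to a double-bonded ring carbon, while the other 3,4,5-trimethoxyphenyl group stays.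

Going by the values given here, no measured step changes this place alone. Among the compounds with values here, the one measured step, a 1.1-fold lower number from compound 1 to compound 3 (0.04 log units; within the scatter), is a swap of acetamido for fluoro elsewhere on the molecule, so it bears only indirectly. The closest hint comes from compound 2, which carries no 3,4,5-trimethoxyphenyl group and gives 7490 nM, against compound 3 at 3470 nM. That pair differs on both sides of the core, so it offers no clean size for a single swap. In this assay, no shift beyond the scatter is therefore expected, and no direction can be favoured. The expected change is a 1.0-fold higher number from compound 1 to compound 4 (0.02 log units; within the scatter). For compound 4 the estimated value is 4000 nM, with an expected range from 1500 nM to 9000 nM.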

Compound 4, half-maximal inhibitory concentration: 4900 nM
Compound 4: the middle estimate sits 1.2-fold (0.09 log units) below what was measured, and the stated range covers the measured number.
By their numbers in this assay, from the lowest: compounds 3, 1, 4 and 2 (each within the scatter of the next, the first and the last beyond it).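

In this assay, going by these compounds alone, the step at this place is a 1.3-fold higher number from compound 1 to compound 4 (0.11 log units; within the scatter), and it gives the first direct reading for 3-nitrophenyl in place of 3,4,5-trimethoxyphenyl on a double-bonded chain carbon bound to a double-bonded ring carbon, where the earlier compounds offered only a swap elsewhere on the molecule. With the other 3,4,5-trimethoxyphenyl group kept, this single pair shows that the exchange of a group of 12 heavy atoms with 3 hydrogen-bond acceptors for one of 9 heavy atoms with 2 such acceptors leaves the number within the scatter, so the full 3,4,5-trimethoxyphenyl group at this place is not needed to stay in this range. No measurement bears on why the two compounds read alike, and the result carries no explanation of its own.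

The compounds shown leave open whether the remaining 3,4,5-trimethoxyphenyl group can be exchanged in the same way, and whether 3-nitrophenyl holds its reading with acetamido in place of fluoro. They also leave open how an aminophenyl or a carboxylic acid-bearing phenyl group would read at this same place.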